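A few compounds are considered here, and "the series" means these few. Any claim that something is new, unique, unknown or untested is made for them only; others in the source may bear on it.

Working notes on the series. Three compounds have numbers in an in vitro functional assay on 1321-N1 cells for agonist activity at P2Y purinoceptor 6 (Homo sapiens); a higher number here means that more compound is needed for the effect, a lower number that less compound is needed. Compound 1 `Cn1c(=O)ccn([C@@H]2O[C@H](COP(=O)(O)OP(=O)(O)O)[C@@H](O)[C@H]2O)c1=O` gives 3300 nM. Compound 2 `O=C(O)CSc1ccn([C@@H]2O[C@H](COP(=O)(O)OP(=O)(O)O)[C@@H](O)[C@H]2O)c(=O)n1` gives 1700 nM. Compound 3 `O=c1ccn([C@]23CC2[C@H](COP(=O)(O)OP(=O)(O)O)[C@@H](O)C3)c(=O)[nH]1` gives 230 nM. Compound 2 has the second highest of the three numbers; its nearest neighbour is compound 1, whose number sits within the scatter of that of compound 2, so no order between the two can be read; compound 3 lies furthest off, with a number beyond the scatter below that of compound 2. Among the compounds with values here, no pair among the measured compounds differs in one place only, so no single step is available for comparison.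

Compound 4 `NC(=O)CSc1ccn([C@@H]2O[C@H](COP(=O)(O)OP(=O)(O)O)[C@@H](O)[C@H]2O)c(=O)n1` has not yet been measured in this assay. It differs from compound 2 as follows: amino in place of hydroxy on a carbonyl carbon. Read one bond further out, the (carboxymethyl)sulfanyl group of compound 2 becomes a (carbamoylmethyl)sulfanyl group in compound 4. Within the data shown here, nothing among the measured compounds shows the effect of such a change, so the expected step from compound 2 to compound 4 is a 1.1-fold lower number from compound 2 to compound 4 (0.05 log units; within the scatter), taken to lie within the scatter. Compound 4 is therefore estimated at 1500 nM in this assay, with a range from 500 nM to 5000 nM.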

Compound 4, half-maximal effective concentration: 18000 nM
Estimate against measurement, compound 4: 12-fold (1.08 log units) below; measured number outside the range, above it.
By their numbers in this assay, from the lowest: compound 3; then compounds 2 and 1 (each within the scatter of the next); then compound 4.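

In this assay, within the data shown here, amino in place of hydroxy on a carbonyl carbon gives an 11-fold higher number from compound 2 to compound 4 (1.02 log units; beyond the scatter) and is the first single-place step available. It shows that the number at this position responds strongly to the end of the (carboxymethyl)sulfanyl group, even though the change replaces one heavy atom with one heavy atom and the hydroxy and amino groups count alike in hydrogen-bond donors and acceptors, so these counts do not separate compound 2 from compound 4. Nothing at hand measures a property that would account for the size of this step.

The compounds shown do not tell whether the step reflects the loss of the carboxy group or the arrival of the carbamoyl group, and a methyl ester or a tetrazole at the same place, or a carboxyethyl group in place of carboxymethyl, would help separate these readings. They also leave open whether the same exchange gives a step of similar size on another core, such as that of compound 3, or with a sulfanyl chain ending in an amine.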